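Rearranging the azole of an EP1 antagonist series

The source may report more compounds than this note shows. Statements on the series, on what has been measured and on what is new or still open speak of the compounds shown alone.

Compound 1, `O=C(O)c1ccn(Cc2cc(Br)ccc2OCc2ccccc2)n1`, is the reference point of this short series. In a functional assay on CHO-K1 cells for antagonist activity at prostaglandin E2 receptor EP1 subtype (Homo sapiens), read by FLIPR (a lower number here means a stronger inhibitor, a higher number a weaker inhibitor), compound 1 gives 55 nM, the lowest of the two numbers available; its nearest neighbour is compound 2, `O=C(O)c1nn(Cc2cc(Br)ccc2OCc2ccccc2)cc1F`, which gives 692 nM in this assay, a change of a 13-fold higher number from compound 1 to compound 2 (1.10 log units; beyond the scatter) brought about by a fluoro in place of hydrogen on an aromatic carbon. Compound 3, `O=C(O)c1nn(Cc2cc(Br)ccc2OCc2ccccc2)cc1C(F)(F)F`, carries a trifluoromethyl at the same aromatic carbon and is reported in this assay only as a limit, < 2000 nM, so that a step that the limit leaves unreadable from compound 1 to compound 3 and a step that the limit leaves unreadable from compound 2 to compound 3 cannot be sized.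

Compound 4, `O=C(O)c1cncn1Cc1cc(Br)ccc1OCc1ccccc1`, differs from compound 1 by 5-carboxy-1H-imidazol-1-yl in place of 3-carboxy-1H-pyrazol-1-yl on a saturated chain carbon bound to an aromatic carbon. For the measured compounds named here, none of the measured steps involves this rearrangement; they all concern substitution on the azole ring and show that the ring tolerates such changes poorly, as compound 2 illustrates with a 13-fold higher number from compound 1 to compound 2 (1.10 log units; beyond the scatter). Going by the values given here, the rearrangement itself, however, has no measured counterpart here, so the expectation rests on the sensitivity of this position alone. Compound 4 is therefore expected to come out somewhat weaker than compound 1, with a step of a 3.6-fold higher number from compound 1 to compound 4 (0.56 log units; beyond the scatter) anticipated. For compound 4 an inhibition constant of 200 nM is estimated in this assay, within a range from 40 nM to 1500 nM.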

Compound 4, inhibition constant: < 2000 nM
Compound 4: no number, only a limit (the forecaster's own chance of this, stated with the estimate: 15%); the middle value lies beyond the limit too.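

In this assay compound 4 is reported only as a limit, so no step from compound 1 to compound 4 can be read: the limit of < 2000 nM in this assay, at which 2 of the 4 values shown sit.

The compounds shown leave open whether 5-carboxy-1H-imidazol-1-yl in place of 3-carboxy-1H-pyrazol-1-yl changes the inhibition constant of compound 1 at all, and by how much.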